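Same Aryl Swap, Carried Onto a Longer Chain

The compounds below may be only part of what the source reports. "The series", "measured", "known", "first", "only" and "open" are said of these compounds alone.

Measured compounds:
- compound 1, `CC(C)=CCC1Cc2c(OC(=O)Nc3cccc(C(F)(F)F)c3)cc(=O)n(CCCO)c2CC1(C)C`, gives 54.3%
- compound 2, `CC(C)=CCC1Cc2c(OC(=O)Nc3ccc(Cl)c(Cl)c3)cc(=O)n(CCCO)c2CC1(C)C`, gives 61.4%
- compound 3, `CC(C)=CCC/C(C)=C/CC1Cc2c(OC(=O)Nc3cccc(C(F)(F)F)c3)cc(=O)n(CCCO)c2CC1(C)C`, gives 44%

These three compounds were tested in a functional assay on PANC-1 cells (Homo sapiens) for inhibition, read by MTT assay, with a stated time of 24 h, tested at 10 uM; on this read-out higher numbers stand for more inhibition at the one concentration tested (going by the name of the read-out) and lower numbers for less inhibition. Compound 1 and compound 2 share one core and differ only by 3,4-dichlorophenyl in place of 3-(trifluoromethyl)phenyl on an amide-type nitrogen; the step was a number 7.1 percentage points higher from compound 1 to compound 2 (within the scatter). Compound 3 carries a different core, which differs from that of compound 1 by 3-methylbut-2-en-1-yl in place of hydrogen on a saturated chain carbon bound to a double-bonded chain carbon; the step was a number 10.3 percentage points lower from compound 1 to compound 3 (beyond the scatter). Compound 3 thus stands lowest of the three, below compound 1 and compound 2 beyond the scatter.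

Compound 4, `CC(C)=CCC/C(C)=C/CC1Cc2c(OC(=O)Nc3ccc(Cl)c(Cl)c3)cc(=O)n(CCCO)c2CC1(C)C`, has not yet been measured. It differs from compound 3 by 3,4-dichlorophenyl in place of 3-(trifluoromethyl)phenyl on an amide-type nitrogen. This is the same change as that from compound 1 to compound 2, made at the same kind of place, but on the core of compound 3 rather than the core of compound 1. The change appears twice among these four compounds, once measured and once not.

Because the measured step of a number 7.1 percentage points higher from compound 1 to compound 2 (within the scatter) was within the scatter, the expected step is small: compound 4 is estimated to move by a number 7 percentage points higher from compound 3 to compound 4 (within the scatter) from compound 3. Compound 4 is therefore expected to give about 51%, with a likely range from 40% to 62%.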

Compound 4, a percentage reported as inhibition, at one concentration (the size of the read-out at that concentration, not a potency): 20%
Estimate against measurement, compound 4: 31 percentage points above; measured number outside the range, below it.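

In this assay, the change to 3,4-dichlorophenyl gave a number 24 percentage points lower from compound 3 to compound 4 (beyond the scatter), so the step measured on the core of compound 1 did not carry over to the core of compound 3: the same change on two cores in this assay, a number 7.1 percentage points higher (within the scatter) from compound 1 to compound 2 and a number 24 percentage points lower (beyond the scatter) from compound 3 to compound 4, 31.1 percentage points apart, beyond the scatter of two such steps. Read the other way, adding the 3-methylbut-2-en-1-yl group gave a number 41.4 percentage points lower from compound 2 to compound 4 (beyond the scatter), a larger drop than the same addition gave with the 3-(trifluoromethyl)phenyl group: the same change on two cores in this assay, a number 10.3 percentage points lower (beyond the scatter) from compound 1 to compound 3 and a number 41.4 percentage points lower (beyond the scatter) from compound 2 to compound 4, 31.1 percentage points apart, beyond the scatter of two such steps. The two changes therefore do not simply add up in these four compounds, and a step measured on one core is a poor guide to the other, but this rests on a single pair per core at one concentration, so it shows neither why the steps differ nor a rule for the wider series.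

The compounds shown leave open how other groups on the amide-type nitrogen, such as a phenyl ring carrying a single chlorine or a methoxy group, would behave on these two cores. Within the data shown here, they also leave open whether a still longer chain in place of the one on compound 3 would give a step closer to that on the core of compound 1 or to that on the core of compound 3.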